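Swapping Hydroxyethyl for Phenyl on a Sulfonamide Nitrogen

This account rests on a few compounds, and the source may have more. Where it says the series, first, only, none or still open, it means among the compounds named here.

Compound 1: `CC[C@@H]1C(=O)N(C)c2cnc(Nc3ccc(S(=O)(=O)NCCO)cc3)nc2N1C1CCCC1` — 278 nM
Compound 2: `CCNC(=O)c1ccc2c(ccn2-c2ncc3c(n2)N(C2CCCC2)[C@H](CC)C(=O)N3C)c1` — 596 nM

Of the compounds shown here, two have been tested in a functional assay on Huh-7 cells (Homo sapiens) for antiproliferative activity, read by CCK-8 assay, with a stated time of 72 h; on this read-out lower numbers stand for stronger inhibition of growth and higher numbers for weaker inhibition of growth. Compound 1 gives 278 nM, the lower of the two numbers, while compound 2 gives 596 nM, a gap that lies beyond the usual scatter. The two structures differ in many places at once, so their gap cannot be traced to any single group.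

Compound 3, `CC[C@@H]1C(=O)N(C)c2cnc(Nc3ccc(S(=O)(=O)Nc4ccccc4)cc3)nc2N1C1CCCC1`, has not yet been measured. It differs from compound 1 in one place: phenyl in place of 2-hydroxyethyl on a sulfonamide nitrogen. Going by the values given here, no pair of measured compounds shows how a change at this position plays out, so the size of the step is open. The step of a 1.4-fold higher number from compound 1 to compound 3 (0.14 log units; within the scatter) is expected to be small, possibly within the scatter, with a slight lean toward weaker inhibition. For compound 3 the estimate is 380 nM, with a range from 120 nM to 1200 nM.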

Compound 3, concentration for 50% growth inhibition: 2790 nM
Compound 3: middle estimate off by 7.3-fold (0.87 log units), on the low side, and the stated range ends below it.
By their numbers in this assay, from the lowest: compound 1; then compound 2; then compound 3.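

The sulfonamide nitrogen is a sensitive position, not a silent one: in this assay, phenyl in place of 2-hydroxyethyl gives a 10-fold higher number from compound 1 to compound 3 (1.00 log units; beyond the scatter), well beyond the scatter and toward weaker inhibition of growth. This is the first change in one place among these compounds, so the size of a step here can now be read directly. The swap brings in a ring and removes the hydrogen-bond donor and acceptor of the chain in a single move, and no separate measurement accounts for the step.

The compounds shown leave open whether the ring that enters or the hydroxyl that leaves matters more. A plain ethyl chain on this nitrogen, a benzyl group, or a longer chain ending in a hydroxyl or an amine would each bear on that question.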